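Working notes: from 2-aminobenzyl to 4-aminobenzyl sulfonyl

The source may hold more compounds than are shown below. What is called first, only, known or untested is meant among the compounds shown, and "the series" means these compounds.

- compound 1 `O=c1c(OC2CCCC2)c(N2CCN(S(=O)(=O)Cc3cccc(C(F)(F)F)c3)CC2)cnn1-c1cccc(Cl)c1`: "not determined" (no result reported)
- compound 2 `Nc1ccccc1CS(=O)(=O)N1CCN(c2cnn(-c3cccc(Cl)c3)c(=O)c2OC2CCCC2)CC1`: 290 ng.h/mL

Within the data shown here, in an ADME assay on the whole organism (plasma) for pharmacokinetics, with Rattus norvegicus as the target, with a stated time of 6 h, at a dose of 10 mg/kg by the oral route (on this read-out lower numbers stand for lower exposure and higher numbers for higher exposure at the dose given), compound 2 gives the only number so far, 290 ng.h/mL. Compound 1 has no result reported, so nothing in the series yet places compound 2 high or low. The unmeasured compound 3 `Nc1ccc(CS(=O)(=O)N2CCN(c3cnn(-c4cccc(Cl)c4)c(=O)c3OC3CCCC3)CC2)cc1` carries the change (4-aminophenyl in place of 2-aminophenyl on a saturated chain carbon bound to a sulfonyl sulfur), that is, 4-aminophenyl in place of 2-aminophenyl on a saturated chain carbon bound to a sulfonyl sulfur. Among the measured compounds shown here, no measured pair shows what such a change does in this assay, and the data support no direction. The expected step of a 1.3-fold lower number from compound 2 to compound 3 (0.12 log units; within the scatter) is none beyond the usual scatter. This expectation rests on compound 2 alone, at 290 ng.h/mL, and the range is kept wide for that reason. The estimated value for compound 3 is 220 ng.h/mL, with an expected range from 60 ng.h/mL to 800 ng.h/mL.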

Compound 3, area under the concentration-time curve: 80 ng.h/mL
Beside the measured number, compound 3's estimate is 2.8-fold (0.44 log units) above it; measured number inside the range.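

In this assay, 4-aminophenyl in place of 2-aminophenyl on a saturated chain carbon bound to a sulfonyl sulfur gives a 3.6-fold lower number from compound 2 to compound 3 (0.56 log units; beyond the scatter). The two compounds have the same atoms, joined differently, so this read-out is sensitive to where the amine sits on the aromatic ring at this position, and not only to which atoms are present. This rests on a single pair, and no measurement shown accounts for the difference.

The compounds shown leave open how an unsubstituted benzyl group, or a benzyl group carrying a carboxylic acid or a nitrile in place of the amine, would read in this assay. On these data alone, it also remains open whether the lower number with 4-aminophenyl would hold if the cyclopentyloxy group on the shared core were replaced by a methoxy group.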